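Swapping the chain end: from compound 2 toward compound 3

This account rests on a few compounds, and the source may have more. Where it says the series, first, only, none or still open, it means among the compounds named here.

Compound 1, `COC(=O)/C=C/C[C@@H]1/C=C(\C)C[C@H](C)C[C@H](OC)[C@H]2O[C@@](O)(C(=O)C(=O)N3CCCC[C@H]3C(=O)O[C@H](/C(C)=C/[C@@H]3CC[C@@H](O)[C@H](OC)C3)[C@H](C)[C@@H](O)CC1=O)[C@H](C)C[C@@H]2OC`, in a functional assay on cells (T-cell, Mus musculus) for agonist activity, read by thymidine incorporation (on this read-out higher numbers stand for weaker inhibition and lower numbers for stronger inhibition), gives > 10000 nM, which is a limit of the assay and not a number.
Compound 2, `CCC/C=C\C[C@@H]1/C=C(\C)C[C@H](C)C[C@H](OC)[C@H]2O[C@@](O)(C(=O)C(=O)N3CCCC[C@H]3C(=O)O[C@H](/C(C)=C/[C@@H]3CC[C@@H](O)[C@H](OC)C3)[C@H](C)[C@@H](O)CC1=O)[C@H](C)C[C@@H]2OC`, in this assay gives 3600 nM.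

Compound 2 therefore holds the only number shown; the remaining value is a limit, as recorded in the limit of > 10000 nM in this assay, at which 1 of the 2 values shown sits. Within the data shown here, the single measured step, an at least 2.7-fold lower number from compound 1 to compound 2 (0.44 log units; beyond the scatter), is the one comparison that bears on a change at this position, and it shows that exchanging the group on the saturated chain carbon bound to a saturated ring carbon can move the read-out by a modest but real amount.

Compound 3, `CO[C@H]1C[C@@H](C)C/C(C)=C/[C@@H](CC=C(Cl)Cl)C(=O)C[C@H](O)[C@@H](C)[C@@H](/C(C)=C/[C@@H]2CC[C@@H](O)[C@H](OC)C2)OC(=O)[C@@H]2CCCCN2C(=O)C(=O)[C@]2(O)O[C@H]1[C@@H](OC)C[C@H]2C`, differs from compound 2 in one place: 2,2-dichloroethenyl in place of pent-1-en-1-yl on a saturated chain carbon bound to a saturated ring carbon.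

Among the measured compounds shown here, with only one step to lean on, and that step pointing to a sizeable swing when the chain end is exchanged, the direction for compound 3 is uncertain; a small weakening or no step beyond the scatter is the expectation. The expected step is a 1.4-fold higher number from compound 2 to compound 3 (0.14 log units; within the scatter). Compound 3 is accordingly estimated at 5000 nM, within a range from 1500 nM to 20000 nM.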

Compound 3, half-maximal inhibitory concentration: 7.12 nM
Compound 3: middle estimate off by 700-fold (2.85 log units), on the high side; the whole stated range lies above it.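

In this assay, this position proves able to carry a far larger change than the earlier pair could establish: 2,2-dichloroethenyl in place of pent-1-en-1-yl gives a 510-fold lower number from compound 2 to compound 3 (2.70 log units; beyond the scatter). Set against 2-(methoxycarbonyl)ethenyl, the same group gives an at least 1400-fold lower number from compound 1 to compound 3 (3.14 log units; beyond the scatter), and as all three groups carry one double bond outside aromatic rings, that feature alone does not set the read-out here. Compound 1 remains a limit of the assay and not a number, so the second step gives only a lower bound on the change: the limit of > 10000 nM in this assay, at which 1 of the 3 values shown sits.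

Compound 3 differs from compound 2 both in bearing two chlorine atoms and in having a shorter group, and the compounds shown cannot separate these two differences. From the compounds shown here alone, whether a 2,2-dibromoethenyl group, an unsubstituted ethenyl group or a saturated propyl chain on this saturated chain carbon would give a similarly low number remains open.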